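The source may hold more compounds than are shown below. What is called first, only, known or untested is meant among the compounds shown, and "the series" means these compounds.

Of the compounds shown here, two that share one core have been tested in a functional assay on HCT-15 cells (Homo sapiens) for cytotoxicity, read by sulforhodamine B assay, with a stated time of 72 h; on this read-out lower numbers stand for stronger inhibition of growth and higher numbers for weaker inhibition of growth. Compound 1, `O=C(Nc1ccccc1O)C1CCc2ccccc2N1C(=O)c1ccccc1Cl`, gives 44900 nM in this assay. Compound 2, `O=C(Nc1ccccc1C(F)(F)F)C1CCc2ccccc2N1`, gives 40400 nM in this assay; this is the lowest of the two numbers, yet the gap to compound 1 lies within the usual scatter, so neither compound can be called the stronger one. Compound 3, `O=C(Nc1ccccc1O)C1CCc2ccccc2N1`, has not yet been measured. It differs from compound 2 in one place: hydroxy in place of trifluoromethyl on an aromatic carbon. Among the measured compounds shown here, no measured pair shows what such a swap does here, so no direction can be taken from earlier results. Both measured values sit at the weak end, so compound 3 is expected to stay close to them, and the step of a 1.1-fold higher number from compound 2 to compound 3 (0.05 log units; within the scatter) is expected to be none beyond the scatter. Compound 3 is therefore estimated at 45000 nM, with a range from 15000 nM to 130000 nM.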

Compound 3, concentration for 50% growth inhibition: 5610 nM
Estimate against measurement, compound 3: 8.0-fold (0.90 log units) above; the whole stated range lies above it.
By their numbers in this assay, from the lowest: compound 3; then compounds 2 and 1 (each within the scatter of the next).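

In this assay, hydroxy in place of trifluoromethyl on an aromatic carbon, ortho to a large group, gives a 7.2-fold lower number from compound 2 to compound 3 (0.86 log units; beyond the scatter), so what sits at this position can change the result well beyond the scatter. Hydrogen in place of (2-chlorophenyl)carbonyl on the nitrogen gives an 8.0-fold lower number from compound 1 to compound 3 (0.90 log units; beyond the scatter), which shows that the hydroxy does not give the lower number on its own: compound 1 carries the hydroxy too, but only compound 3 combines it with the unsubstituted nitrogen. No measurement at hand explains why either change has this effect.

Going by these compounds, it remains open whether a methoxy, an amine or plain hydrogen on the same aromatic carbon would match hydroxy. On these data alone, it is also open whether a small group such as acetyl on the nitrogen would be tolerated.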